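Methylsulfonyl for methylcarbamoyl on a cytotoxicity plateau

This account rests on a few compounds, and the source may have more. Where it says the series, first, only, none or still open, it means among the compounds named here.

Three analogues sharing one core have been assessed in an ADME assay on BaF3 cells (Mus musculus) for cytotoxicity; a higher number here means that more compound is needed for the effect, a lower number that less compound is needed. Compound 1 `Nc1cccc(-c2cc(Nc3ccc(OC(F)(F)F)cc3)ncn2)c1` gives only a limit of the assay, > 10000 nM. Compound 2 `NS(=O)(=O)c1cccc(-c2cc(Nc3ccc(OC(F)(F)F)cc3)ncn2)c1` likewise gives only a limit, > 10000 nM. Compound 3 `CNC(=O)c1cccc(-c2cc(Nc3ccc(OC(F)(F)F)cc3)ncn2)c1` too reaches only a limit, > 10000 nM. Hence the steps a step that the two limits leave unreadable from compound 1 to compound 2, a step that the two limits leave unreadable from compound 1 to compound 3 and a step that the two limits leave unreadable from compound 2 to compound 3 cannot be sized, all three values sitting at the limit of > 10000 nM in this assay, at which 3 of the 3 values shown sit. Compound 3 therefore stands nowhere distinguishable from its two neighbours in this assay. Compound 4 `CS(=O)(=O)c1cccc(-c2cc(Nc3ccc(OC(F)(F)F)cc3)ncn2)c1` is the compound not yet measured; it differs from compound 3 by methylsulfonyl in place of methylcarbamoyl on an aromatic carbon. Among the measured compounds shown here, no measured step bears readably on this change, so nothing in the data points to a direction. With every measured analogue at the limit of this assay, compound 4 is expected to sit there as well, and the expected step from compound 3 to compound 4 is a step that the limit leaves unreadable from compound 3 to compound 4, which is no step beyond the scatter that could be read. For compound 4 the estimate is 15000 nM, between 6000 nM and 40000 nM.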

Compound 4, half-maximal effective concentration: > 10000 nM
Compound 4 gave a limit, no number; the forecaster's own chance of this, stated with the estimate: 85%; the middle value lies beyond the limit too.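

No new step can be read between compound 4 and compound 1, compound 2 or compound 3, because all four compounds give only a limit: the limit of > 10000 nM in this assay, at which 4 of the 4 values shown sit.

The compounds shown leave open whether methylsulfonyl, methylcarbamoyl, sulfamoyl and amino differ at all in this assay.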